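This account rests on a few compounds, and the source may have more. Where it says the series, first, only, none or still open, it means among the compounds named here.

Going by the values given here, compound 2 `Cc1nc(NCc2ccccc2)nc(N[C@@H]2C[C@H](CO)[C@@H](O)[C@H]2O)c1-c1nc2ccccc2s1` is the one compound here with a numbered result: in an ADME assay on cells (Homo sapiens) for cytotoxicity, read by polymerase chain reaction, with a stated time of 3 days (on this read-out higher numbers stand for lower toxicity in this test and lower numbers for higher toxicity in this test), compound 2 gives 9000 nM. Compound 1 `Cc1nc(Nc2ncco2)nc(N[C@@H]2C[C@H](CO)[C@@H](O)[C@H]2O)c1-c1nc2ccccc2s1` reaches only a limit of the assay, > 25000 nM, in this assay. Among the compounds with values here, the one measured step, an at least 2.7-fold lower number from compound 1 to compound 2 (0.44 log units; beyond the scatter), rests on the limit of > 25000 nM in this assay, at which 1 of the 2 values shown sits, and so shows only how small it could at least be. Compound 3 `Cc1nc(NCc2cccnc2)nc(N[C@@H]2C[C@H](CO)[C@@H](O)[C@H]2O)c1-c1nc2ccccc2s1` differs from compound 2 by pyridin-3-yl in place of phenyl on a saturated chain carbon bound to a nitrogen on an aromatic ring. Within the data shown here, no measured step exchanges one six-membered aromatic ring for another at this position, so that step does not bear directly on the present change. The change expected in this assay is therefore none beyond the usual scatter, and compound 3 is expected to give 10000 nM, within 4500 nM and 22000 nM. The step this estimate means is a 1.1-fold higher number from compound 2 to compound 3 (0.05 log units; within the scatter), expected to stay inside the scatter.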

Compound 3, half-maximal cytotoxic concentration: 5000 nM
Beside the measured number, compound 3's estimate is 2.0-fold (0.30 log units) above it; measured number inside the range.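

In this assay, a 1.8-fold lower number from compound 2 to compound 3 (0.26 log units; within the scatter), so putting a ring nitrogen into the aromatic ring at this place gives no difference that can be told from the scatter. Replacing 1,3-oxazol-2-yl on the nitrogen with (pyridin-3-yl)methyl gives an at least 5.0-fold lower number from compound 1 to compound 3 (0.69 log units; beyond the scatter), so the step already seen with benzyl recurs with a second ring, and compound 1 stands apart from compound 2 and compound 3. This step gives only a minimum size, since compound 1 carries a limit of the assay rather than a number: the limit of > 25000 nM in this assay, at which 1 of the 3 values shown sits.

As far as these compounds go, whether pyridin-2-yl, pyridin-4-yl, a saturated ring such as piperidin-4-yl, or a longer chain between the ring and the nitrogen would behave the same way stays open. From the compounds shown here alone, how far compound 1 truly lies from the other two also stays open.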